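Chalcone series: fluoro in place of hydrogen on compound 3

This account rests on a few compounds, and the source may have more. Where it says the series, first, only, none or still open, it means among the compounds named here.

Compound 1 `COc1cc(OC)c(OC)cc1/C=C/C(=O)c1ccc(O)cc1O` gives 37600 nM in a functional assay on HeLa cells (Homo sapiens) for inhibition, read by MTT assay, with a stated time of 72 h; on this read-out lower numbers stand for stronger inhibition and higher numbers for weaker inhibition.
Compound 2 `COc1cc(OC)c(OC)cc1/C=C/C(=O)c1ccc(-c2c[nH]cn2)cc1` gives only a limit, > 150000 nM, in this assay.
Compound 3 `COc1cc(OC)c(OC)cc1/C=C/C(=O)c1ccccc1` gives only a limit, > 150000 nM, in this assay.

Compound 3 stands at the limit of this assay, and the limit of > 150000 nM in this assay, at which 2 of the 3 values shown sit, shows that two of the three values rest there. Compound 4 `COc1cc(OC)c(OC)cc1/C=C/C(=O)c1ccc(F)cc1` differs from compound 3 by fluoro in place of hydrogen on an aromatic carbon. The step of an at least 3.9-fold higher number from compound 1 to compound 3 (0.60 log units; beyond the scatter) concerns the group on the carbonyl carbon, and the step that the two limits leave unreadable from compound 2 to compound 3 cannot be read between two limits. Neither bears on fluoro in place of hydrogen, so no step beyond the scatter is expected in this assay, and compound 4 is expected to stay at or near the limit. Compound 4 is estimated at 150000 nM, within 50000 nM to 300000 nM, a step of a number no higher from compound 3 to compound 4 (the limit leaves the size open).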

Compound 4, half-maximal inhibitory concentration: 28600 nM
Compound 4: middle estimate off by 5.2-fold (0.72 log units), on the high side; the measured number lies below the stated range.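

Fluoro on an aromatic carbon, para to a large group, turns a limit into a measurable value in this assay: the change reads as an at least 5.2-fold lower number from compound 3 to compound 4 (0.71 log units; beyond the scatter), and the replacement of 1H-imidazol-4-yl reads as an at least 5.2-fold lower number from compound 2 to compound 4 (0.71 log units; beyond the scatter). Against 2,4-dihydroxyphenyl, 4-fluorophenyl gives a 1.3-fold lower number from compound 1 to compound 4 (0.12 log units; within the scatter), so these two groups cannot be told apart in this assay. The full size of the first two steps stays open because compound 2 and compound 3 are limits: the limit of > 150000 nM in this assay, at which 2 of the 4 values shown sit.

On these data alone, whether chloro, an amine or a carboxylic acid in the same place would also give a measurable value remains open.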